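Flavone-7-carboxylic acids: gastric inhibition, repositioned methyl

The compounds below may be only part of what the source reports. "The series", "measured", "known", "first", "only" and "open" are said of these compounds alone.

Measured in a functional assay on the whole organism (stomach) for inhibition, with Rattus norvegicus as the target, at a dose of 80 mg/kg; on this read-out higher numbers stand for more inhibition at the one dose given (going by the name of the read-out) and lower numbers for less inhibition:
compound 1 `CCCCCCc1ccc(-c2cc(=O)c3cc(C(=O)O)ccc3o2)cc1` gives 2%
compound 2 `O=C(O)c1ccc2oc(-c3ccc(F)cc3)cc(=O)c2c1` gives 21%
compound 3 `Cc1ccccc1-c1oc2ccc(C(=O)O)cc2c(=O)c1O` gives 15%

Compound 3 stands second of the three numbers in this assay; its value and that of compound 2 lie within the usual scatter of each other, while compound 1 lies beyond it. Compound 4 `Cc1ccc(-c2oc3ccc(C(=O)O)cc3c(=O)c2O)cc1` is not yet measured. It differs from compound 3 as follows: 4-methylphenyl in place of 2-methylphenyl on an aromatic carbon. Within the data shown here, the only measured step, a number 19 percentage points higher from compound 1 to compound 2 (beyond the scatter), concerns a different change at the same position and offers no direct guide to moving a methyl on the pendant ring. No step beyond the scatter is therefore expected; the change no change at the digits printed from compound 3 to compound 4 (within the scatter) is estimated to be small. Compound 4 is expected to give 15%, within a range of 4% to 30%.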

Compound 4, a percentage reported as inhibition, in the whole organism at one dose (the size of the read-out at that dose, not a potency): 6%
Compound 4: the middle estimate sits 9 percentage points above what was measured; the measured number falls inside the stated range.
By their numbers in this assay, from the lowest: compounds 1, 4, 3 and 2 (each within the scatter of the next, the first and the last beyond it).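

In this assay, 4-methylphenyl in place of 2-methylphenyl gives a number 9 percentage points lower from compound 3 to compound 4 (within the scatter), so this read-out does not separate the two placements of the methyl. Unlike the hexyl-to-fluoro swap, this change keeps the same atoms and alters only how they are joined, and it stays inside the usual scatter. Nothing available gives a cause for this result. The compounds shown leave open whether an amine or a carboxylic acid in place of the methyl would move the number beyond the scatter in this assay.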